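A few compounds are considered here, and "the series" means these few. Any claim that something is new, unique, unknown or untested is made for them only; others in the source may bear on it.

Measured compounds:
- compound 1 `CCCCCCN(Cc1ccc(C(=O)NO)cc1)c1ncc(-c2ccc(C)cc2)s1`: 3710 nM
- compound 2 `Cc1ccc(OCCCN(Cc2ccc(C(=O)NO)cc2)c2ncc(-c3ccc(C)cc3)s2)cc1`: 32500 nM

In a functional assay on A549 cells (Homo sapiens) for antiproliferative activity, read by MTT assay, with a stated time of 48 h (on this read-out lower numbers stand for stronger inhibition of growth and higher numbers for weaker inhibition of growth), compound 1 gives 3710 nM and compound 2 gives 32500 nM. Compound 1 stands as the lowest of the two numbers shown; the single measured step is an 8.8-fold higher number from compound 1 to compound 2 (0.94 log units; beyond the scatter), in which a 4-methylphenoxy is put in place of propyl on a saturated chain carbon, three bonds along the chain from a nitrogen on an aromatic ring.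

Compound 3 `CCCN(Cc1ccc(C(=O)NO)cc1)c1ncc(-c2ccc(C)cc2)s1` differs from compound 1 by hydrogen in place of propyl on a saturated chain carbon, three bonds along the chain from a nitrogen on an aromatic ring. Within the data shown here, no measured step removes this propyl; the one step known touches the same place but adds a 4-methylphenoxy instead, so it bears only loosely on the change, showing that this position is sensitive to what is attached there. On that basis a modest shift to a higher number is expected for compound 3, as a 2.0-fold higher number from compound 1 to compound 3 (0.31 log units; beyond the scatter), with wide uncertainty. Compound 3 is estimated at 7500 nM, within 2500 nM to 25000 nM.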

Compound 3, concentration for 50% growth inhibition: 3310 nM
Beside the measured number, compound 3's estimate is 2.3-fold (0.36 log units) above it; low and high end bracket the measured number.
By their numbers in this assay, from the lowest: compounds 3 and 1 (each within the scatter of the next); then compound 2.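

In this assay, going from hexyl to propyl on the nitrogen gives a 1.1-fold lower number from compound 1 to compound 3 (0.05 log units; within the scatter), so the outer propyl of compound 1 can be lost without a change that stands out from the scatter. The step of a 9.8-fold lower number from compound 2 to compound 3 (0.99 log units; beyond the scatter) is of about the same size as the step of an 8.8-fold higher number from compound 1 to compound 2 (0.94 log units; beyond the scatter), which sets the 4-methylphenoxy apart: at this position hydrogen and propyl read alike, and only the 4-methylphenoxy gives a higher number. No measurement available here explains this difference.

Still open, on these data alone, is whether the higher number follows the phenyl ring of the 4-methylphenoxy or its ether oxygen, which a plain phenoxy or a phenyl at the chain end would help separate. Also open, as far as these compounds go, is how a terminal amine or carboxylic acid on the propyl chain would read.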